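Fluoro for methoxy on the benzyl ring of compound 3

The source may hold more compounds than are shown below. What is called first, only, known or untested is meant among the compounds shown, and "the series" means these compounds.

Compound 1, `Nc1n/c(=N\CCCCc2ccccc2)nc(N)c2c1ncn2Cc1ccccc1`: 8800 nM
Compound 2, `CCCCCCCC/N=c1\nc(N)c2ncn(Cc3ccccc3)c2c(N)n1`: 4550 nM
Compound 3, `CCCCCCCC/N=c1\nc(N)c2ncn(Cc3ccc(OC)cc3)c2c(N)n1`: 3800 nM

These three compounds share one core and were tested in a functional assay on MCF7 cells (Homo sapiens) for antiproliferative activity, read by WST assay, with a stated time of 72 h; a higher number here means a weaker inhibitor, a lower number a stronger inhibitor. Compound 3 holds the lowest of the three numbers, though its gap to compound 2 lies within the scatter, so no order between those two can be read; only compound 1 stands apart, beyond the scatter above compound 3.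

Compound 4, `CCCCCCCC/N=c1\nc(N)c2ncn(Cc3ccc(F)cc3)c2c(N)n1`, has not yet been measured. It differs from compound 3 in one place: fluoro in place of methoxy on an aromatic carbon.

Neither measured step bears directly on this change. The step of a 1.9-fold lower number from compound 1 to compound 2 (0.29 log units; within the scatter) alters a distant chain, and the step of a 1.2-fold lower number from compound 2 to compound 3 (0.08 log units; within the scatter) adds the very methoxy group that compound 4 now loses again; that step stayed within the scatter. The closest guide is therefore that methoxy against hydrogen at this position made no difference beyond the scatter, and a fluoro group in the same spot gives no reason in these data to expect more.

Compound 4 is thus expected to sit near compound 3, with a step of about a 1.1-fold higher number from compound 3 to compound 4 (0.04 log units; within the scatter), that is no change beyond the scatter. The estimated value of compound 4 in this assay is 4200 nM, expected between 2000 nM and 9000 nM.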

Compound 4, half-maximal inhibitory concentration: 3000 nM
Compound 4: the middle estimate sits 1.4-fold (0.15 log units) above what was measured; low and high end bracket the measured number.
By their numbers in this assay, from the lowest: compounds 4, 3, 2 and 1 (each within the scatter of the next, the first and the last beyond it).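

In this assay fluoro in place of methoxy gives a 1.3-fold lower number from compound 3 to compound 4 (0.10 log units; within the scatter) and fluoro in place of hydrogen gives a 1.5-fold lower number from compound 2 to compound 4 (0.18 log units; within the scatter) on the same aromatic carbon. The earlier compounds shown here compared only methoxy with hydrogen here, whereas three groups can now be set side by side, and none of them stands beyond the scatter of another. Even the exchange of methoxy, which carries a hydrogen-bond acceptor, for fluoro, which is counted with none, leaves the number within the scatter, and no measurement shown accounts for these small steps.

The compounds shown leave open whether a different group on this aromatic carbon, such as an amine, a carboxylic acid or a nitrile, would move the number beyond the scatter. Within the data shown here, they also leave open whether fluoro and methoxy would behave the same way with the chain of compound 1 or with a longer chain on the double-bonded nitrogen in place of the one these three compounds share.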